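This account rests on a few compounds, and the source may have more. Where it says the series, first, only, none or still open, it means among the compounds named here.

Measured in a functional assay on HepG2 cells (Homo sapiens) for antiproliferative activity, read by MTT assay, with a stated time of 72 h; on this read-out higher numbers stand for weaker inhibition and lower numbers for stronger inhibition:
- compound 1 `COc1ncc(-c2ccc3c(c2)N(c2ccc(C)cc2)C(=O)CO3)cc1NS(=O)(=O)c1ccc(F)cc1` gives 28300 nM
- compound 2 `O=C1COc2ccc(-c3cccc(NS(=O)(=O)c4ccc(F)cc4)c3)cc2N1C1CC1` reaches only the limit of the assay, > 40000 nM, which is a limit and not a number
- compound 3 `O=C1COc2ccc(-c3cnc(Cl)c(NS(=O)(=O)c4ccc(F)cc4)c3)cc2N1c1ccccc1` gives 35700 nM

Compound 3 holds the highest of the two numbers reported, but compound 1 sits so close that the gap between them lies within the usual scatter, so no order between compound 1 and compound 3 can be read. The third value, that of compound 2, is a limit only (the limit of > 40000 nM in this assay, at which 1 of the 3 values shown sits). Among the measured compounds shown here, no two measured compounds differ in a single place, so no measured step is available to lean on; the whole set sits at the weak end of this assay.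

Compound 4 `COc1ccc(N2C(=O)COc3ccc(-c4cnc(Cl)c(NS(=O)(=O)c5ccc(F)cc5)c4)cc32)cc1` is the next member and differs from compound 3 by methoxy in place of hydrogen on an aromatic carbon. The methoxy enters on an aromatic carbon of a six-membered aromatic ring of carbon only, para to a large group; cut one bond further out, the change reads phenyl to 4-methoxyphenyl. With no measured step of this kind in the series, the expectation in this assay is a step within the scatter, in no set direction. Compound 4 is therefore estimated at 30000 nM, between 10000 nM and 80000 nM, which means an expected step of a 1.2-fold lower number from compound 3 to compound 4 (0.08 log units; within the scatter).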

Compound 4, half-maximal inhibitory concentration: > 40000 nM
Compound 4 ended at the assay's limit; the forecaster's own chance of this, stated with the estimate: 35%; middle value at least 1.3-fold (0.12 log units) from the limit.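

Notes on the series, in this assay: this is the first measured step in one place, methoxy in place of hydrogen on an aromatic carbon, para to a large group, and it reads an at least 1.1-fold higher number from compound 3 to compound 4 (0.04 log units; that floor lies within the scatter). On these data alone, compound 4 gives > 40000 nM, which is a limit and not a number, so the true size of the step stays unknown, its floor lies within the scatter, and phenyl to 4-methoxyphenyl gives no sign of stronger inhibition at this place. The change also adds one more compound to those that give no number in this assay, leaving the series with fewer values that can be ordered: the limit of > 40000 nM in this assay, at which 2 of the 4 values shown sit.

As far as these compounds go, whether the same place tolerates or rewards another group, such as an amine, a carboxylic acid or a longer chain like propoxy, stays open, as does whether any such group would bring a compound to a number inside the range of the assay. With a single step at this place, and that one bounded only on one side, no trend for this position can be stated.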